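The source may hold more compounds than are shown below. What is called first, only, known or untested is meant among the compounds shown, and "the series" means these compounds.

Of the compounds shown here, three that share a common core have been tested in a functional assay on MCF7 cells (Homo sapiens) for inhibition, read by MTT assay, with a stated time of 72 h; a higher number here means a weaker inhibitor, a lower number a stronger inhibitor. Compound 1 `CC(C)(C)OC(=O)N1CCN(C(=S)SCc2cn(Cc3cc(=O)oc4cc(O)ccc34)nn2)CC1` gives 10400 nM. Compound 2 `COc1ccc(Cn2cc(CSC(=S)N3CCN(C(=O)OCc4ccccc4)CC3)nn2)cc1` gives 30500 nM, and compound 3 `S=C(SCc1cn(Cc2ccccc2Cl)nn1)N1CCNCC1` gives 38900 nM. Among these three numbers compound 2 stands second highest: its number and that of compound 3 lie within the scatter of each other, so nothing separates the two, while compound 1 shows a lower number, a gap that lies beyond the scatter.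

Compound 4 `COc1cc(Cn2cc(CSC(=S)N3CCN(C(=O)OCc4ccccc4)CC3)nn2)cc(OC)c1OC` has not yet been measured. It differs from compound 2 in one place only: 3,4,5-trimethoxyphenyl in place of 4-methoxyphenyl on a saturated chain carbon bound to an aromatic nitrogen. Going by the values given here, no pair of measured compounds shows this same change, so there is no measured step to lean on; the three measured compounds differ from one another in several places at once.

The expectation is therefore cautious. The step from compound 2 to compound 4 in this assay is expected to be small and to point toward a lower number, without clearly leaving the scatter: a 1.9-fold lower number from compound 2 to compound 4 (0.28 log units; within the scatter). For compound 4 the estimate in this assay is 16000 nM, with an expected range from 5000 nM to 50000 nM within which most repeated measurements should fall.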

Compound 4, half-maximal inhibitory concentration: > 128000 nM
Compound 4: only a limit was reported; the forecaster's own chance of this, stated with the estimate: 10%; middle value at least 8.0-fold (0.90 log units) away from the limit.
By their numbers in this assay, from the lowest: compound 1; then compounds 2 and 3 (each within the scatter of the next). At a limit, above all of these: compound 4.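

Going by these compounds alone, the group on the saturated chain carbon bound to an aromatic nitrogen clearly matters in this assay, something the earlier compounds could not show because they differ from one another in several places at once. Putting 3,4,5-trimethoxyphenyl in place of 4-methoxyphenyl gives an at least 4.1-fold higher number from compound 2 to compound 4 (0.62 log units; beyond the scatter), so in this single pair the larger group with more methoxy substituents makes a weaker inhibitor rather than a stronger one. Compound 4 is known only through a limit, so how much weaker it is remains unknown, and the step gives only the smallest size it can have: the limit of > 128000 nM in this assay, at which 1 of the 4 values shown sits.

One pair cannot tell whether the loss follows from the number of methoxy groups or from the particular 3,4,5-trimethoxyphenyl arrangement, and it says nothing about how a plain phenyl group, or a ring carrying an amine or a carboxylic acid, would behave at this place. On these data alone, it also remains open whether the same change would weaken inhibition on the rest of compound 1 or compound 3, which differ from compound 2 in several places.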